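The compounds below may be only part of what the source reports. "The series", "measured", "known", "first", "only" and "open" are said of these compounds alone.

Compound 1, `Cc1ccccc1-c1nnc(NNC2CCCC2)s1`, gives a limit in a functional assay on the whole organism with Mus musculus as the target, in the maximal electroshock model, with a stated time of 1 h; on this read-out lower numbers stand for an effect already at smaller amounts and higher numbers for an effect only at larger amounts of compound: > 100 mg/kg.
Compound 2, `CNN(C)c1nnc(-c2ccccc2C)s1`, gives 10 mg/kg in this assay.
Compound 3, `Cc1ccccc1-c1nnc(N(C)NC(C)C)s1`, gives 35 mg/kg in this assay.

Among the two numbers shown, compound 3 stands highest; its nearest neighbour is compound 2, and the step of a 3.5-fold higher number from compound 2 to compound 3 (0.54 log units; beyond the scatter) lies beyond the scatter. The value of compound 1 is a limit of the assay and not a number (the limit of > 100 mg/kg in this assay, at which 1 of the 3 values shown sits), so it cannot be placed in order with the others.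

Compound 4, `Cc1ccccc1-c1nnc(NN(C)C(C)C)s1`, differs from compound 3 in one place: a group of 6 heavy atoms (4 carbon, 2 nitrogen; no ring) in place of a group of 6 heavy atoms (4 carbon, 2 nitrogen; no ring), on an aromatic carbon. The two have the same atoms, joined differently.

For the measured compounds named here, only one measured step is at hand, a 3.5-fold higher number from compound 2 to compound 3 (0.54 log units; beyond the scatter), and it concerns a different change, the growth of a methyl into an isopropyl on an amine nitrogen, rather than a rearrangement of the same atoms. Compound 1, which carries a cyclopentyl on the amine and no methyl, gave only a limit. No step shown bears directly on the change from compound 3 to compound 4, so a small step is expected, likely within the scatter, with a modest chance of a higher number.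

For compound 4 a value of 40 mg/kg is estimated, within 15 mg/kg to 120 mg/kg, which would mean an expected step of a 1.1-fold higher number from compound 3 to compound 4 (0.06 log units; within the scatter).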

Compound 4, dose for half-maximal effect: 140 mg/kg
Beside the measured number, compound 4's estimate is 3.5-fold (0.54 log units) below it; measured number above the stated range.
By their numbers in this assay, from the lowest: compound 2; then compound 3; then compound 4.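

In this assay, the atoms at this aromatic carbon need only be joined differently for the number to move: a 4.0-fold higher number from compound 3 to compound 4 (0.60 log units; beyond the scatter). The group that leaves, (isopropylamino)(methyl)amino, and the one that enters have the same heavy atoms and the same counts of hydrogen-bond donors and acceptors, so these counts and the atoms alone do not fix the number, something the earlier step, which added atoms, could not show. The larger step, a 14-fold higher number from compound 2 to compound 4 (1.15 log units; beyond the scatter), places compound 4 highest of the numbers shown, while the step to compound 1 cannot be read, as compound 1 gives a limit and not a number: the limit of > 100 mg/kg in this assay, at which 1 of the 4 values shown sits.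

The compounds shown leave open whether the arrangement of compound 4 keeps the same effect when a smaller group, such as an ethyl, or a cyclopropyl takes the place of its isopropyl. They also leave open whether the step from compound 3 to compound 4 would hold if a chlorine replaced the methyl on the other ring of the shared core.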